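Bromo in place of iodo on a haloketone chain

A few compounds are considered here, and "the series" means these few. Any claim that something is new, unique, unknown or untested is made for them only; others in the source may bear on it.

Compound 1, `Cc1cn(C2CC(O)C(CCC(=O)CCl)O2)c(=O)[nH]c1=O`, in an ADME assay for pharmacokinetics (a lower number here means that the compound disappears faster, a higher number that the compound lasts longer), gives > 52 h, which is a limit of the assay rather than a number. Compound 2, `Cc1cn(C2CC(O)C(CCC(=O)CI)O2)c(=O)[nH]c1=O`, in this assay gives 4 h.

Going by the values given here, compound 2 therefore holds the only actual number in this assay; the one other value is a limit. The new compound 3, `Cc1cn(C2CC(O)C(CCC(=O)CBr)O2)c(=O)[nH]c1=O`, differs from compound 2 in one place: bromo in place of iodo on a saturated chain carbon bound to a carbonyl carbon. Among the compounds with values here, the only measured step that bears on this is an at least 13-fold lower number from compound 1 to compound 2 (1.11 log units; beyond the scatter), a large drop, though its size is only known as a lower bound because compound 1 sits at the limit of > 52 h in this assay, at which 1 of the 2 values shown sits. Bromo lies between chloro and iodo in that series, so a move back toward a longer half-life is expected, but smaller than the full measured step. For compound 3 the estimate is 12 h, with a likely range of 5 h to 35 h, meaning an expected step of a 3.0-fold higher number from compound 2 to compound 3 (0.48 log units; beyond the scatter).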

Compound 3, half-life: 1.8 h
For compound 3 the middle estimate is 6.7-fold (0.82 log units) above the measured one, and the stated range ends above it.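

In this assay, the halogen on this saturated chain carbon bound to a carbonyl carbon does not act as a simple sliding scale. Replacing iodo with bromo gives a 2.2-fold lower number from compound 2 to compound 3 (0.35 log units; beyond the scatter), so compound 3, not compound 2, has the shortest half-life of the compounds shown, and half-life does not change steadily from chloro through bromo to iodo. Replacing chloro with bromo gives the larger change, an at least 28-fold lower number from compound 1 to compound 3 (1.46 log units; beyond the scatter), whose size is only a lower bound: the limit of > 52 h in this assay, at which 1 of the 3 values shown sits.

As far as these compounds go, it remains open whether this uneven order extends to fluoro, the one common halogen absent here, or whether a hydroxyl or an amine in the halogen's place would give a longer half-life. From the compounds shown here alone, the role of the ketone carbonyl also remains open, as it is the same in all three compounds.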